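Swapping the Chlorophenyl Amide for a Thiophene Amide

This account rests on a few compounds, and the source may have more. Where it says the series, first, only, none or still open, it means among the compounds named here.

Compound 2 `CC(C)OC(=O)C1=CN(C(=O)c2cccc(Cl)c2)CC(C)(C)c2cc(C#N)[nH]c21` carries a 3-chlorophenyl on the carbonyl carbon. In an assay on HEK293 cells for agonist activity at Bile acid receptor (Homo sapiens), read by a luciferase reporter (on this read-out lower numbers stand for smaller maximal responses and higher numbers for larger maximal responses), compound 2 gives 122%, and compound 1 `CC(C)OC(=O)C1=CN(C(=O)c2ccc(F)cc2)CC(C)(C)c2cc(C#N)[nH]c21` gives 119%, two numbers that lie within the scatter of each other. Going by the values given here, the only measured step, a number 3 percentage points higher from compound 1 to compound 2 (within the scatter), shows that exchanging one substituted phenyl for another left the maximal response essentially unchanged. Compound 3 `CC(C)OC(=O)C1=CN(C(=O)c2cccs2)CC(C)(C)c2cc(C#N)[nH]c21` differs from compound 2 by thiophen-2-yl in place of 3-chlorophenyl on a carbonyl carbon. Among the compounds with values here, no measured step covers a change of this kind, so the expected step of a number 7 percentage points lower from compound 2 to compound 3 (within the scatter) is none beyond the scatter. Compound 3 is therefore estimated at 115%, within a range from 95% to 135%.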

Compound 3, largest response reached (reported as efficacy), in percent of the reference or control that the assay uses: 114%
Compound 3: the middle estimate sits 1 percentage points above what was measured; the measured number falls inside the stated range.
By their numbers in this assay, from the lowest: compounds 3, 1 and 2 (each within the scatter of the next).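

Thiophen-2-yl brings a five-membered aromatic ring with a sulfur atom to this carbonyl carbon, and the steps to it from both phenyl compounds stay small (a number 8 percentage points lower from compound 2 to compound 3 (within the scatter); a number 5 percentage points lower from compound 1 to compound 3 (within the scatter)). The maximal response at this position therefore does not depend on a substituted phenyl or on a six-membered ring among these compounds. Nothing at hand explains this result.

As far as these compounds go, all three groups here are aromatic rings, so it remains open how a non-aromatic group, such as cyclohexyl or a longer alkyl chain, would behave on this carbonyl carbon. From the compounds shown here alone, the effect of a ring carrying an amine or a carboxylic acid also remains open.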